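This account rests on a few compounds, and the source may have more. Where it says the series, first, only, none or still open, it means among the compounds named here.

The measured compounds:
compound 1 `CCc1ccccc1-n1nncc1CN1C(=O)C2(C(C#N)=C(N)Oc3c(N)cc4nc5ccccc5nc4c32)c2ccccc21`, which gives 10300 nM in a functional assay on HCT-116 cells (Homo sapiens) for antiproliferative activity, read by MTT assay, with a stated time of 48 h; on this read-out higher numbers stand for weaker inhibition and lower numbers for stronger inhibition;
compound 2 `CCc1cccc(CC)c1-n1nncc1CN1C(=O)C2(C(C#N)=C(N)Oc3c(N)cc4nc5ccccc5nc4c32)c2ccccc21`, which gives 37600 nM in this assay;
compound 3 `N#CC1=C(N)Oc2c(N)cc3nc4ccccc4nc3c2C12C(=O)N(Cc1cnnn1-c1ccc(Cl)cc1Cl)c1ccccc12`, which in this assay reaches only a limit of > 50000 nM.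

Compound 3 therefore stands at the limit of > 50000 nM in this assay, at which 1 of the 3 values shown sits, and has no number of its own. Compound 4 `N#CC1=C(N)Oc2c(N)cc3nc4ccccc4nc3c2C12C(=O)N(Cc1cnnn1-c1cc(Cl)ccc1Cl)c1ccccc12` differs from it by 2,5-dichlorophenyl in place of 2,4-dichlorophenyl on an aromatic nitrogen. Within the data shown here, no measured step exchanges one dichlorophenyl for another: the aryl swaps an at least 4.8-fold higher number from compound 1 to compound 3 (0.68 log units; beyond the scatter) and an at least 1.3-fold higher number from compound 2 to compound 3 (0.12 log units; that floor lies within the scatter) both end at the limit, and the step of a 3.7-fold higher number from compound 1 to compound 2 (0.56 log units; beyond the scatter) concerns an added ethyl. On this evidence one expects no step beyond the scatter in this assay, with compound 4 most likely again reported as a limit. The estimate for compound 4 is 60000 nM, within 20000 nM to 200000 nM, which amounts to an expected step that the limit leaves unreadable from compound 3 to compound 4.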

Compound 4, half-maximal inhibitory concentration: > 50000 nM
Compound 4: no number, only a limit (the forecaster's own chance of this, stated with the estimate: 70%); the middle value does not contradict the limit.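

In this assay, exchanging 2,4-dichlorophenyl for 2,5-dichlorophenyl yields no number for either compound, and the step between compound 3 and compound 4 cannot be read because both are limits: the limit of > 50000 nM in this assay, at which 2 of the 4 values shown sit.

Replacing 2-ethylphenyl with 2,5-dichlorophenyl gives an at least 4.8-fold higher number from compound 1 to compound 4 (0.68 log units; beyond the scatter), so a second dichlorophenyl group also separates from that ethyl-bearing aryl group. Replacing 2,6-diethylphenyl with it gives an at least 1.3-fold higher number from compound 2 to compound 4 (0.12 log units; that floor lies within the scatter), which does not separate the two.

As far as these compounds go, how far apart the two dichlorophenyl groups truly lie stays open. So does what a single chlorine, a methoxy group or an amine on this phenyl ring would give.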